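This account rests on a few compounds, and the source may have more. Where it says the series, first, only, none or still open, it means among the compounds named here.

The measured compounds:

- compound 1, `Cc1cnc(Nc2ccc(S(C)(=O)=O)cc2)nc1Nc1nc2ccccc2s1`: 14800 nM
- compound 2, `NS(=O)(=O)c1ccc(Nc2ncc(F)c(Nc3nc4ccc(Cl)cc4s3)n2)cc1`: 2790 nM
- compound 3, `Cc1cnc(Nc2ccc(S(N)(=O)=O)cc2)nc1Nc1nc2ccccc2s1`: 16800 nM

All three were tested in a functional assay on MDA-MB-231 cells (Homo sapiens) for antiproliferative activity, read by MTT assay, with a stated time of 48 h; a lower number here means a stronger inhibitor, a higher number a weaker inhibitor. In this assay compound 2 gives the lowest of the three numbers, and its gap to compound 1 and to compound 3 is beyond the usual scatter, so compound 2 is the strongest inhibitor of the measured set. Compound 2 and compound 3 differ in several places at once, and the difference between the two cores is not broken down here.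

Compound 3 and compound 1 share a core and differ in one spot: methyl in place of amino on a sulfonyl sulfur. This change made the step of a 1.1-fold lower number from compound 3 to compound 1 (0.06 log units; within the scatter), a step small enough to sit within the scatter of repeated measurements.

Compound 4, `CS(=O)(=O)c1ccc(Nc2ncc(F)c(Nc3nc4ccc(Cl)cc4s3)n2)cc1`, is not yet measured. It stands to compound 2 exactly as compound 1 stands to compound 3: methyl in place of amino on a sulfonyl sulfur. The surroundings of the change are the same in both pairs, so this is the same change applied to a different core.

The expectation for compound 4 rests on that single earlier example. Because a 1.1-fold lower number from compound 3 to compound 1 (0.06 log units; within the scatter) was within the scatter, the step from compound 2 to compound 4 is expected to be similarly small, a 1.1-fold lower number from compound 2 to compound 4 (0.05 log units; within the scatter). Compound 4 is therefore estimated at 2500 nM in this assay, with a plausible range from 1000 nM to 6500 nM.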

Compound 4, half-maximal inhibitory concentration: 11100 nM
The estimate for compound 4 lay 4.4-fold (0.65 log units) below the measured number; measured number outside the range, above it.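

On the core of compound 2, methyl in place of amino on the sulfonyl sulfur has a clear effect in this assay, with a 4.0-fold higher number from compound 2 to compound 4 (0.60 log units; beyond the scatter). Set beside the earlier example, the same change did not carry over unchanged from one core to the other: the same change on two cores in this assay, a 1.1-fold lower number (0.06 log units; within the scatter) from compound 3 to compound 1 and a 4.0-fold higher number (0.60 log units; beyond the scatter) from compound 2 to compound 4, 4.5-fold (0.65 log units) apart, beyond the scatter of two such steps. Among these compounds, this shows that, in this series, a swap with almost no effect on one core cannot be assumed to be as harmless on another, but it does not show why the two cores respond differently, since they differ in several places at once and only one pair per core is available.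

As far as these compounds go, it remains open which of those core differences decides the size of the step, a question that compounds changing one core feature at a time, with either sulfonyl group kept in place, could address. From the compounds shown here alone, it also remains open whether other groups on the sulfonyl sulfur, such as an ethyl chain or a dimethylamino group, would sit nearer compound 2 or compound 4 in this assay.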